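The compounds below may be only part of what the source reports. "The series", "measured", "known", "first", "only" and "open" are said of these compounds alone.

Measured in a functional assay on A549 cells (Homo sapiens) for inhibition, read by MTT assay, with a stated time of 72 h; on this read-out higher numbers stand for weaker inhibition and lower numbers for stronger inhibition:
- compound 1 `CC(C)(C)n1cc2c(n1)C(=O)CC1(CCN(C(=O)c3cc(-c4ccccc4)nc4ccccc34)CC1)O2`: 1940 nM
- compound 2 `CC(C)(C)n1cc2c(n1)C(=O)CC1(CCN(C(=O)c3cc(-c4ccccn4)nc4ccccc34)CC1)O2`: 7720 nM
- compound 3 `CN1CCN(c2cc(C(=O)N3CCC4(CC3)CC(=O)c3nn(C(C)(C)C)cc3O4)c3ccccc3n2)CC1`: > 10000 nM (a limit of the assay, not a number)

Compound 3 stands at the limit of > 10000 nM in this assay, at which 1 of the 3 values shown sits. Its exact value is therefore unknown. The next compound, compound 4 `CC(C)Oc1cc(C(=O)N2CCC3(CC2)CC(=O)c2nn(C(C)(C)C)cc2O3)c2ccccc2n1`, keeps the shared core and carries isopropoxy in place of 4-methylpiperazin-1-yl on an aromatic carbon, next to the ring nitrogen: isopropoxy in place of 4-methylpiperazin-1-yl on an aromatic carbon.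

Within the data shown here, three measured steps concern this same carbon. Pyridin-2-yl in place of phenyl gives a 4.0-fold higher number from compound 1 to compound 2 (0.60 log units; beyond the scatter). 4-methylpiperazin-1-yl in place of phenyl gives an at least 5.1-fold higher number from compound 1 to compound 3 (0.71 log units; beyond the scatter). 4-methylpiperazin-1-yl in place of pyridin-2-yl gives an at least 1.2-fold higher number from compound 2 to compound 3 (0.11 log units; that floor lies within the scatter). Among these three compounds, then, the group on this carbon does change the read-out, by modest steps so far. Isopropoxy itself has not been measured here, so no step speaks to it directly. Starting from a limit, the expected direction in this assay is towards a lower number, by a modest step, though compound 4 may also stay at the limit.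

For compound 4 the estimated value is 5000 nM, with an expected range from 2000 nM to 10000 nM. The expected change is an at least 2.0-fold lower number from compound 3 to compound 4 (0.30 log units; that floor lies within the scatter).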

Compound 4, half-maximal inhibitory concentration: > 10000 nM
Compound 4: no number, only a limit (the forecaster's own chance of this, stated with the estimate: 30%); middle value at least 2.0-fold (0.30 log units) away from the limit.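

In this assay compound 4 gives > 10000 nM, a limit of the assay and not a number. With compound 3 also at a limit, the step between these two compounds cannot be read, and the limit now holds a second group on this carbon: the limit of > 10000 nM in this assay, at which 2 of the 4 values shown sit.

Isopropoxy, which carries no ring, therefore joins 4-methylpiperazin-1-yl at the limit, and among these four compounds only phenyl and pyridin-2-yl give a number, with the replacement showing an at least 5.1-fold higher number from compound 1 to compound 4 (0.71 log units; beyond the scatter) and an at least 1.2-fold higher number from compound 2 to compound 4 (0.11 log units; that floor lies within the scatter), so that compound 4 is separated from compound 1 but not from compound 2.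

As far as these compounds go, how far compound 3 and compound 4 lie beyond the limit remains unknown, so the two groups cannot be ranked against each other. The compounds shown also leave open whether methoxy, dimethylamino or a substituted aromatic group such as 4-methoxyphenyl on this carbon would give a number, and whether any such group would match or improve on phenyl.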